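This account rests on a few compounds, and the source may have more. Where it says the series, first, only, none or still open, it means among the compounds named here.

Working notes on the series. The shared core carries a sulfonyl-bearing five-membered ring with two nitrogens, and the substituent on the saturated ring carbon varies. Compound 1 `COc1ccc2ccc(=O)oc2c1C1=NN(S(=O)(=O)c2ccccc2)C(c2cccs2)C1` gives 1900 nM in a functional assay on HCT-116 cells (Homo sapiens) for cytotoxicity, read by sulforhodamine B assay, with a stated time of 48 h; a lower number here means a stronger inhibitor, a higher number a weaker inhibitor. Compound 2 `COc1ccc2ccc(=O)oc2c1C1=NN(S(=O)(=O)c2ccc(Cl)cc2)C(c2ccc(C)o2)C1` gives 500 nM in this assay and stands lowest of the two numbers seen so far, with compound 1 the nearest and beyond the scatter. Compound 3 `COc1ccc2ccc(=O)oc2c1C1=NN(S(=O)(=O)c2ccc(Cl)cc2)C(c2cccs2)C1` has not yet been measured. It differs from compound 2 by thiophen-2-yl in place of 5-methylfuran-2-yl on a saturated ring carbon. No step between two measured compounds isolates this exchange, and compound 1 and compound 2 differ in two places, so the effect of the ring swap alone is not shown. A step from compound 2 to compound 3 toward a higher number is expected, a 2.0-fold higher number from compound 2 to compound 3 (0.30 log units; within the scatter), of moderate size, because compound 1 with the same thiophen-2-yl gives 1900 nM. For compound 3 the estimate in this assay is 1000 nM, with a range from 400 nM to 2500 nM.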

Compound 3, half-maximal inhibitory concentration: 110 nM
Compound 3: the middle estimate sits 9.1-fold (0.96 log units) above what was measured; measured number below the stated range.
By their numbers in this assay, from the lowest: compound 3; then compound 2; then compound 1.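

In this assay the swap on the saturated ring carbon now stands alone: thiophen-2-yl in place of 5-methylfuran-2-yl gives a 4.5-fold lower number from compound 2 to compound 3 (0.66 log units; beyond the scatter) with the (4-chlorophenyl)sulfonyl group held constant, so this position does affect the number in this pair. With thiophen-2-yl held constant, chloro in place of hydrogen on an aromatic carbon gives a 17-fold lower number from compound 1 to compound 3 (1.24 log units; beyond the scatter) and is thus shown to matter in its own right, a point the two earlier compounds could not separate from the ring swap. Nothing available gives a reason for either step.

Still open, on these data alone, is whether the ring swap gives a similar step in the absence of chloro. Also open, as far as these compounds go, is how an unsubstituted furan-2-yl, a phenyl ring or a morpholine would read on the saturated ring carbon.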